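The source may hold more compounds than are shown below. What is called first, only, known or untested is meant among the compounds shown, and "the series" means these compounds.

Among the measured compounds shown here, compound 3 `FC(F)(F)c1ccc(CSc2nc(Nc3ccccc3Cl)c3ccccc3n2)cc1` is one of three compounds measured in a functional assay on PC-3 cells (Homo sapiens) for cytotoxicity, read by MTT assay, with a stated time of 72 h (a lower number here means a stronger inhibitor, a higher number a weaker inhibitor), where compound 3 gives 20400 nM. Its two neighbours are compound 1 `FC(F)(F)c1ccc(CSc2nc(N3CCCCC3)c3ccccc3n2)cc1`, which in this assay gives 25500 nM, and compound 2 `FC(F)(F)c1ccc(CSc2nc(Nc3ccccc3)c3ccccc3n2)cc1`, which gives 20000 nM. Neither neighbour stands apart from compound 3: the step of a 1.3-fold lower number from compound 1 to compound 3 (0.10 log units; within the scatter) and the step of a 1.0-fold higher number from compound 2 to compound 3 (0.01 log units; within the scatter) both sit within the scatter, as does a 1.3-fold lower number from compound 1 to compound 2 (0.11 log units; within the scatter), so the three numbers cannot be ordered.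

Compound 4 `CCOc1ccccc1Nc1nc(SCc2ccc(C(F)(F)F)cc2)nc2ccccc12` has not yet been measured in this assay. Relative to compound 3 the change is ethoxy in place of chloro on an aromatic carbon. For the measured compounds named here, the only measured step touching the same position of the aromatic ring is that from compound 2 to compound 3, where chloro replaced hydrogen and the number barely moved; the exchange of the whole substituent on the core, seen from compound 1 to compound 2 and from compound 1 to compound 3, was likewise small. Going by the values given here, with no step so far leaving the scatter, compound 4 is expected to follow suit, with an estimated step of a 1.0-fold lower number from compound 3 to compound 4 (0.01 log units; within the scatter) that stays within it. Compound 4 is therefore estimated at 20000 nM, with a range from 8000 nM to 50000 nM.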

Compound 4, half-maximal inhibitory concentration: 26200 nM
Beside the measured number, compound 4's estimate is 1.3-fold (0.12 log units) below it; the range from low to high includes it.
By their numbers in this assay, from the lowest: compounds 2, 3, 1 and 4 (each within the scatter of the next).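

In this assay, this position, ortho to a large group, accepts ethoxy with its 3 heavy atoms and 1 hydrogen-bond acceptor, giving a 1.3-fold higher number from compound 3 to compound 4 (0.11 log units; within the scatter) against chloro and a 1.3-fold higher number from compound 2 to compound 4 (0.12 log units; within the scatter) against hydrogen, where the earlier compounds had shown only chloro in place of hydrogen. Among the compounds shown here, the whole (2-ethoxyphenyl)amino group also stays level with piperidin-1-yl on the core, at a 1.0-fold higher number from compound 1 to compound 4 (0.01 log units; within the scatter) and so extends to a third substituent on the ring the flat picture the earlier compounds gave. No evidence is available that bears on this result.

The compounds shown leave open whether an amine, a carboxylic acid or a longer chain such as butoxy at this position would take the number beyond the scatter. For the compounds shown here, they also leave open whether any change at this position can be read at all, since every step so far stays within the scatter.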